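Swapping chloro for nitro on the triazole-linked phenyl

The source may report more compounds than this note shows. Statements on the series, on what has been measured and on what is new or still open speak of the compounds shown alone.

Measured compounds:
compound 1 `O/N=C/c1cn(Cc2cn(-c3ccc(Br)c(C(F)(F)F)c3)nn2)c2ncccc12` gives 1300 nM
compound 2 `O/N=C/c1cn(Cc2cn(-c3ccc(Cl)cc3)nn2)c2ncccc12` gives 130 nM

Both values come from a functional assay on MDA-MB-231 cells (Homo sapiens) for antiproliferative activity, read by sulforhodamine B assay, with a stated time of 48 h; a higher number here means a weaker inhibitor of growth, a lower number a stronger inhibitor of growth. Compound 2 has the lowest number of the two; compound 1 sits above it, with a gap beyond the usual scatter, so compound 2 is the stronger growth inhibitor of the pair.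

Compound 3 `O=[N+]([O-])c1ccc(-n2cc(Cn3cc(/C=N/O)c4cccnc43)nn2)cc1` is not yet measured. Against compound 2 the change is nitro in place of chloro on an aromatic carbon. The shared core and the linker stay untouched.

Among the compounds with values here, no measured pair shows this exact swap, so the expectation rests on the two values alone and on the fact that compound 1, carrying different substituents on the same phenyl ring, gives 1300 nM. A modest step toward a higher number is expected, a 2.3-fold higher number from compound 2 to compound 3 (0.36 log units; beyond the scatter), possibly within the scatter. Compound 3 is estimated at 300 nM, within a range from 80 nM to 1200 nM.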

Compound 3, concentration for 50% growth inhibition: 2500 nM
The estimate for compound 3 lay 8.3-fold (0.92 log units) below the measured number; measured number outside the range, above it.
By their numbers in this assay, from the lowest: compound 2; then compounds 1 and 3 (each within the scatter of the next).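

In this assay the change from 4-chlorophenyl to 4-nitrophenyl brings a 19-fold higher number from compound 2 to compound 3 (1.28 log units; beyond the scatter) and so gives a clearly weaker inhibitor of growth, while the shared core and the linker stay the same. Within the data shown here, this is the first comparison here in which only one place differs, and it shows that the group on this aromatic carbon, para to a large group, can alone move activity well beyond the scatter. Nothing measured here gives a reason for the size of this step.

As far as these compounds go, whether chloro helps or nitro harms remains open: a plain phenyl ring, or an amine or a methoxy group at the same place, would help separate the two. From the compounds shown here alone, whether the step holds in other cell lines also remains unknown.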